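This account rests on a few compounds, and the source may have more. Where it says the series, first, only, none or still open, it means among the compounds named here.

Series notes, the step from compound 1 to compound 4.

Among the measured compounds shown here, compound 1 `CN1C[C@H](C(=O)Nc2ccc(C#N)cc2)[C@@H](c2ccc(/C=C/C(=O)Nc3ccccc3N)cc2)C1` is the anchor of the three measured members. In an in vitro ADME assay on microsomes from liver (Homo sapiens) for pharmacokinetics, read by LC-MS, with a stated time of 10 min, tested at 1 uM (a higher number here means faster removal of the compound, a lower number slower removal), compound 1 gives 1 mL/min/kg, the lowest number among the three, and both other members sit beyond the scatter above it. Compound 2 `CN1C[C@H](C(=O)Nc2cccc(F)c2)[C@@H](c2ccc(/C=C/C(=O)Nc3ccccc3N)cc2)C1` gives 6 mL/min/kg in this assay, and compound 3 `Cc1cccc(NC(=O)[C@H]2CN(C)C[C@@H]2c2ccc(/C=C/C(=O)Nc3ccccc3N)cc2)c1` gives 14 mL/min/kg.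

The change to compound 4 `CN1C[C@H](C(=O)Nc2ccc(F)c(Br)c2)[C@@H](c2ccc(/C=C/C(=O)Nc3ccccc3N)cc2)C1` is 3-bromo-4-fluorophenyl in place of 4-cyanophenyl on an amide-type nitrogen. The two measured steps that bear on it both leave the same 4-cyanophenyl from the same amide-type nitrogen: a 6.0-fold higher number from compound 1 to compound 2 (0.78 log units; beyond the scatter) and a 14-fold higher number from compound 1 to compound 3 (1.15 log units; beyond the scatter). Between those two products, a 2.3-fold higher number from compound 2 to compound 3 (0.37 log units; beyond the scatter). Each time the 4-cyanophenyl is removed from compound 1 the number rises beyond the scatter, with the size depending on what enters; the 3-bromo-4-fluorophenyl carries a fluorine, as in compound 2, with a bromine added.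

The expectation for compound 4 is therefore a rise beyond the scatter, of roughly an 8.0-fold higher number from compound 1 to compound 4 (0.90 log units; beyond the scatter), placing it between the numbers of compound 2 and compound 3 rather than back near compound 1. The estimate for compound 4 in this assay is 8 mL/min/kg, expected to fall between 2.5 mL/min/kg and 25 mL/min/kg.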

Compound 4, clearance: 15 mL/min/kg
For compound 4 the middle estimate is 1.9-fold (0.27 log units) below the measured one; measured number inside the range.
By their numbers in this assay, from the lowest: compound 1; then compound 2; then compounds 3 and 4 (each within the scatter of the next).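

In this assay, a third replacement of the 4-cyanophenyl on the amide-type nitrogen again raises the number beyond the scatter (a 15-fold higher number from compound 1 to compound 4 (1.18 log units; beyond the scatter)), so compound 2, compound 3 and compound 4 all stand above compound 1, and none of the three goes against this. Sharing a fluorine does not keep the 3-bromo-4-fluorophenyl with the 3-fluorophenyl (a 2.5-fold higher number from compound 2 to compound 4 (0.40 log units; beyond the scatter)), while the comparison with the 3-methylphenyl shows no separation (a 1.1-fold higher number from compound 3 to compound 4 (0.03 log units; within the scatter)), so two differently substituted rings here give numbers within the scatter of each other. The compounds shown offer no measurement that accounts for any of these differences.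

Among the compounds shown here, compound 1 (1 mL/min/kg) remains the only member with a nitrile, so it is open whether the low number belongs to that group or to the 4-cyanophenyl as a whole. Also open, from the compounds shown here alone, is where the number would fall with an amine or a carboxylic acid on the phenyl ring, or with a longer chain in place of that ring on the amide-type nitrogen.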